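Estimating cytotoxicity of a fourth analogue from three measurements

This account rests on a few compounds, and the source may have more. Where it says the series, first, only, none or still open, it means among the compounds named here.

Compound 1 `FC(F)(F)c1ccc(-c2ccc3c(NCCCNCc4ccco4)ccnc3c2)cc1`: 3470 nM
Compound 2 `c1ccc(Cc2ccc3c(NCCCNCc4ccco4)ccnc3c2)cc1`: 16000 nM
Compound 3 `COc1cccc(CNCCCNc2ccnc3cc(-c4ccc(C(F)(F)F)cc4)ccc23)c1O`: 2210 nM

These values come from an ADME assay on HepG2 cells (Homo sapiens) for cytotoxicity, read by luminescence, CellTiter-Glo and ATP content, with a stated time of 72 h; a lower number here means that less compound is needed, a higher number that more compound is needed for the effect. Compound 3 has the lowest number of the three, but its step to compound 1 lies within the scatter, so no order is claimed between them. Compound 4 `COc1cccc(CNCCCNc2ccnc3cc(Cc4ccccc4)ccc23)c1O` remains to be measured in this assay. It differs from compound 3 by benzyl in place of 4-(trifluoromethyl)phenyl on an aromatic carbon, the same change as that made from compound 1 to compound 2, namely (benzyl in place of 4-(trifluoromethyl)phenyl on an aromatic carbon), which gave a 4.6-fold higher number from compound 1 to compound 2 (0.66 log units; beyond the scatter). The two cores differ by 2-hydroxy-3-methoxyphenyl in place of furan-2-yl on a saturated chain carbon bound to an amine nitrogen, a change that gave a 1.6-fold lower number from compound 1 to compound 3 (0.20 log units; within the scatter). Going by the values given here, with only one earlier example of the change, the expected step is taken to be of similar size, a 4.5-fold higher number from compound 3 to compound 4 (0.66 log units; beyond the scatter), resting on a 4.6-fold higher number from compound 1 to compound 2 (0.66 log units; beyond the scatter). Compound 4 is therefore estimated at 10000 nM, expected to fall between 5000 nM and 20000 nM.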

Compound 4, half-maximal effective concentration: 5720 nM
For compound 4 the middle estimate is 1.7-fold (0.24 log units) above the measured one; the range from low to high includes it.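

In this assay, benzyl in place of 4-(trifluoromethyl)phenyl on the second core gave a 2.6-fold higher number from compound 3 to compound 4 (0.41 log units; beyond the scatter), and this step does not differ from the earlier one: the same change on two cores in this assay, a 4.6-fold higher number (0.66 log units; beyond the scatter) from compound 1 to compound 2 and a 2.6-fold higher number (0.41 log units; beyond the scatter) from compound 3 to compound 4, 1.8-fold (0.25 log units) apart, within the scatter of two such steps. The other change, 2-hydroxy-3-methoxyphenyl in place of furan-2-yl, gave a 2.8-fold lower number from compound 2 to compound 4 (0.45 log units; beyond the scatter), and it too carried over: the same change on two cores in this assay, a 1.6-fold lower number (0.20 log units; within the scatter) from compound 1 to compound 3 and a 2.8-fold lower number (0.45 log units; beyond the scatter) from compound 2 to compound 4, 1.8-fold (0.25 log units) apart, within the scatter of two such steps. Going by these compounds alone, this shows that each change transferred between these two cores, but with only two cores and one pair of groups per change, it does not show that either would transfer across the wider series.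

The compounds shown leave open whether a chlorine atom or a morpholine on the same aromatic carbon, or a longer chain on the amine side, would behave alike. What lies behind either step also remains open.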